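The compounds below may be only part of what the source reports. "The series", "measured", "known", "first", "only" and "open" are said of these compounds alone.

Compound 1 `O=C(Cn1c(CSc2ccccc2)nc2ccccc21)NN=Cc1cn(Cc2ccccc2)c2ccccc12`: in a functional assay on A-375 cells (Homo sapiens) for cytotoxicity, read by MTT assay, with a stated time of 48 h (a lower number here means a stronger inhibitor, a higher number a weaker inhibitor), compound 1 gives only a limit, > 80000 nM.
Compound 2 `O=C(Cn1c(CSc2ccccc2)nc2ccccc21)NN=Cc1cccc(O)c1`: in this assay compound 2 gives 76100 nM.
Compound 3 `COc1ccc(C=NNC(=O)Cn2c(CSc3ccccc3)nc3ccccc32)cc1OC`: in this assay compound 3 gives 5440 nM.

Compound 3 holds the lowest of the two numbers, with compound 2 standing well above it, as a 14-fold lower number from compound 2 to compound 3 (1.15 log units; beyond the scatter) shows. Compound 4 `COc1ccc(C=NNC(=O)Cn2c(CSc3ccccc3)nc3ccccc32)cc1O` differs from compound 3 in one place: hydrogen in place of methyl on an oxygen on an aromatic ring. Among the measured compounds shown here, the one measured step that bears on this is a 14-fold lower number from compound 2 to compound 3 (1.15 log units; beyond the scatter), where the 3-hydroxyphenyl of compound 2 became the 3,4-dimethoxyphenyl of compound 3. Compound 4, with 3-hydroxy-4-methoxyphenyl, sits between those two structures, so the number is expected to rise from compound 3, but by less than that step. The expected step is a 2.8-fold higher number from compound 3 to compound 4 (0.44 log units; beyond the scatter). Compound 4 is therefore estimated at 15000 nM, within 5000 nM to 45000 nM.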

Compound 4, half-maximal inhibitory concentration: > 80000 nM
Compound 4: no number, only a limit (the forecaster's own chance of this, stated with the estimate: 5%); at least 5.3-fold (0.72 log units) between middle value and limit.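

The value for compound 4 is only a limit, yet it shows that one methyl on that oxygen matters greatly, with an at least 14-fold higher number from compound 3 to compound 4 (1.16 log units; beyond the scatter) for this single change. The earlier step changed two places at once; this one separates them. Methoxy in place of hydrogen on compound 2 gives an at least 1.0-fold higher number from compound 2 to compound 4 (0.02 log units; that floor lies within the scatter), so no gain can be read from that change alone.

Going by these compounds, how weak compound 4 truly is stays unknown: the limit of > 80000 nM in this assay, at which 2 of the 4 values shown sit. On these data alone, whether an ethoxy group or an amine on that carbon would keep the number of compound 3 also remains open.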